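A Bromophenyl Sulfonamide Beside Three Near-Identical Weak Inhibitors

The source may hold more compounds than are shown below. What is called first, only, known or untested is meant among the compounds shown, and "the series" means these compounds.

Three compounds were measured in a functional assay on MDA-MB-468 cells (Homo sapiens) for antiproliferative activity, read by MTT assay, with a stated time of 72 h; a lower number here means a stronger inhibitor, a higher number a weaker inhibitor:
compound 1 `CCOC(=O)c1oc2ccc(NS(=O)(=O)c3ccccc3C)cc2c1C`: 53400 nM
compound 2 `CCOC(=O)c1oc2ccc(NS(=O)(=O)c3ccc(Cl)cc3)cc2c1C`: 44000 nM
compound 3 `CCOC(=O)c1oc2ccc(NS(=O)(=O)c3cccc(Cl)c3)cc2c1C`: 53700 nM

Compound 1 gives the second highest of the three numbers. Its nearest neighbour is compound 3, with a 1.0-fold higher number from compound 1 to compound 3 (0.00 log units; within the scatter); its furthest is compound 2, with a 1.2-fold lower number from compound 1 to compound 2 (0.08 log units; within the scatter). The change to compound 4 `CCOC(=O)c1oc2ccc(NS(=O)(=O)c3ccc(Br)cc3)cc2c1C` is 4-bromophenyl in place of 2-methylphenyl on a sulfonyl sulfur. For the measured compounds named here, the steps that bear on it all exchange the aryl group on the sulfonyl sulfur: a 1.2-fold lower number from compound 1 to compound 2 (0.08 log units; within the scatter), a 1.0-fold higher number from compound 1 to compound 3 (0.00 log units; within the scatter) and a 1.2-fold higher number from compound 2 to compound 3 (0.09 log units; within the scatter), none beyond the scatter. Compound 4 is therefore expected to show no step beyond the scatter from compound 1, namely a 1.2-fold lower number from compound 1 to compound 4 (0.06 log units; within the scatter). The estimate for compound 4 is 46000 nM, ranging from 25000 nM to 90000 nM.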

Compound 4, half-maximal inhibitory concentration: 26400 nM
Compound 4: the middle estimate sits 1.7-fold (0.24 log units) above what was measured; the measured number falls inside the stated range.
By their numbers in this assay, from the lowest: compounds 4, 2, 1 and 3 (each within the scatter of the next, the first and the last beyond it).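

Among the exchanges of the aryl group on the sulfonyl sulfur, 4-bromophenyl is the first to give steps beyond the scatter, though both are modest (a 2.0-fold lower number from compound 1 to compound 4 (0.31 log units; beyond the scatter); a 2.0-fold lower number from compound 3 to compound 4 (0.31 log units; beyond the scatter)). Bromo in place of chloro on an aromatic carbon stays within the scatter (a 1.7-fold lower number from compound 2 to compound 4 (0.22 log units; within the scatter)), so compound 4 is not separated from compound 2. No measurement shown explains these steps.

Going by these compounds, whether a 4-iodophenyl or 4-methoxyphenyl group would fall with compound 4 remains open, as does the effect of a carboxylic acid in place of the ester on the shared core.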